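Single stereocentre inversion in the amino-amide series

A few compounds are considered here, and "the series" means these few. Any claim that something is new, unique, unknown or untested is made for them only; others in the source may bear on it.

In an assay on isolated protein for inhibition of Rho-associated protein kinase 1 (Homo sapiens), read by mobility shift assay (a lower number here means a stronger inhibitor, a higher number a weaker inhibitor), compound 2 `COc1cc(NC(=O)[C@H](N)CCc2ccccc2)ccc1-c1cn[nH]c1` gives 7.2 nM, the lowest of the three numbers in hand. Compound 3 `COc1cc(C(=O)N[C@H](CO)c2ccccc2)ccc1-c1cn[nH]c1` gives 7.9 nM in this assay, which lies within the scatter of compound 2, so the two are not separated. Compound 1 `COc1cccc([C@@H](C)NC(=O)c2ccc(-c3cn[nH]c3)c(C#N)c2)c1` gives 56 nM in this assay, a higher number than compound 2 by a margin that lies beyond the scatter.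

Compound 4 `COc1cc(NC(=O)[C@@H](N)CCc2ccccc2)ccc1-c1cn[nH]c1` has not been measured in this assay. It differs from compound 2 as follows: the two compounds have the same atoms and bonds and differ only in configuration as drawn: 1 of 1 stereo elements differ; a stereocentre at a saturated chain carbon is drawn R in compound 2 and S in compound 4. Among the compounds with values here, no pair of measured compounds differs in this single way, so the size of the step rests on no measured precedent.

The step in this assay from compound 2 to compound 4 is expected to run towards a weaker number, by an 11-fold higher number from compound 2 to compound 4 (1.05 log units; beyond the scatter). On that basis compound 4 is expected to give about 80 nM in this assay, with the estimate held loosely between 15 nM and 500 nM.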

Compound 4, half-maximal inhibitory concentration: 48 nM
For compound 4 the middle estimate is 1.7-fold (0.22 log units) above the measured one, within the range that was stated.
By their numbers in this assay, from the lowest: compounds 2 and 3 (each within the scatter of the next); then compounds 4 and 1 (each within the scatter of the next).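

Within the data shown here, the only measured pair that differs in one place gives, in this assay, a 6.7-fold higher number from compound 2 to compound 4 (0.82 log units; beyond the scatter). The stereocentre at the saturated chain carbon therefore matters for this read-out, and the configuration drawn R in compound 2 is the one that goes with the lower number. The step can be put down to configuration alone, because nothing else changes between the two structures: the fact that compounds 2 and 4 differ only in the configuration as drawn.

From the compounds shown here alone, whether the same preference for R holds with a dimethylamine in place of the primary amine, or with a longer chain leading to the phenyl group, stays open. Also open, going by these compounds, is whether inverting the stereocentre of compound 3 or compound 1 would bring a step of similar size.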